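Oxazolyl for Pyridyl at the Aromatic Carbon of Compound 2

A few compounds are considered here, and "the series" means these few. Any claim that something is new, unique, unknown or untested is made for them only; others in the source may bear on it.

Measured compounds:
Compound 1 `CCS(=O)(=O)Nc1cccc2c1CCC2c1ncc[nH]1` — 86%
Compound 2 `c1ccc(-c2cccc3c2CCC3c2ncc[nH]2)nc1` — 53%
Compound 3 `CS(=O)(=O)Nc1c(Cl)ccc2c1CCCC2c1ncc[nH]1` — 61%

In a functional assay on CHO cells for agonist activity at Alpha-1A adrenergic receptor (Homo sapiens), read by FLIPR and calcium flux (on this read-out lower numbers stand for smaller maximal responses and higher numbers for larger maximal responses), compound 2 gives 53%, the lowest of the three numbers; compound 3 sits within the scatter of it, while compound 1 stands apart, the step being a number 33 percentage points lower from compound 1 to compound 2 (beyond the scatter). Compound 4 `c1cc(-c2ncco2)c2c(c1)C(c1ncc[nH]1)CC2` is the unmeasured partner, differing from compound 2 as follows: 1,3-oxazol-2-yl in place of pyridin-2-yl on an aromatic carbon.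

Going by the values given here, only one measured step touches this position, and it compares pyridin-2-yl with (ethylsulfonyl)amino, not with 1,3-oxazol-2-yl; no measured pair shows one five-membered heteroaromatic ring replacing a six-membered one. The account can therefore only note that a change at this carbon moved the maximal response well beyond the scatter once, from compound 1 to compound 2. Exchanging one aromatic heterocycle for another is expected to move the number less, and the step of a number 2 percentage points higher from compound 2 to compound 4 (within the scatter) is estimated to stay close to the scatter. Compound 4 is thus expected to give about 55%, with a range from 35% to 78%.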

Compound 4, largest response reached (Emax), in percent of the reference or control that the assay uses: 63%
Beside the measured number, compound 4's estimate is 8 percentage points below it; low and high end bracket the measured number.
By their numbers in this assay, from the lowest: compounds 2, 3 and 4 (each within the scatter of the next); then compound 1.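

In this assay, the exchange of one aromatic ring for another on this aromatic carbon gives a number 10 percentage points higher from compound 2 to compound 4 (within the scatter), so pyridin-2-yl and 1,3-oxazol-2-yl cannot be told apart here, despite their different ring sizes and hetero atoms. The step of a number 23 percentage points lower from compound 1 to compound 4 (beyond the scatter) adds a second case of an aromatic ring in place of (ethylsulfonyl)amino. With the shared core unchanged, the gap from compound 1 is thus not tied to pyridin-2-yl alone, though it is smaller here and rated modest.

Going by these compounds, whether an amine, a carboxylic acid or a non-aromatic ring such as morpholine on this carbon would give a response closer to that of compound 1 or to that of compound 4 stays open. Nothing available explains the response at this position.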